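The source may hold more compounds than are shown below. What is called first, only, known or untested is meant among the compounds shown, and "the series" means these compounds.

Of the compounds shown here, three built on one shared core have been measured in a functional assay on ileum for antagonist activity at histamine H1 receptor (Cavia porcellus); on this read-out lower numbers stand for tighter binding and higher numbers for weaker binding. Compound 1 `N=C(NCCCc1c[nH]cn1)NCCSC(c1ccccc1)c1ccccn1` gives 100 nM. Compound 2 `COc1ccc(C(CC/N=C(\N)NCCCc2c[nH]cn2)c2ccccn2)cc1` gives 269 nM. Compound 3 `N=C(NCCCc1c[nH]cn1)NCCC(c1ccc(Br)cc1)c1ccccn1` gives 120 nM. Among these three numbers compound 3 stands second highest; its nearest neighbour is compound 1, whose number lies within the usual scatter of this assay, so no order between the two can be read, while compound 2 stands furthest off, with a higher number that lies beyond the scatter.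

Compound 4 `N=C(NCCCc1c[nH]cn1)NCCC(c1ccc(Cl)c(Cl)c1)c1ccccn1` has not yet been measured in this assay. It differs from compound 3 in one place: 3,4-dichlorophenyl in place of 4-bromophenyl on a saturated chain carbon bound to an aromatic carbon and a saturated chain carbon. Among the measured compounds shown here, no pair of measured compounds shows a step of this kind, so the measured data give no direct guide for it. Compound 3 is taken as the point of reference, with 120 nM as the starting number. The expected step, a 1.2-fold lower number from compound 3 to compound 4 (0.08 log units; within the scatter), is small and most likely none beyond the scatter in either direction, with a slight lean toward a lower number. Compound 4 is therefore estimated at 100 nM, with a range from 40 nM to 300 nM.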

Compound 4, dissociation constant: 79.4 nM
Compound 4: the middle estimate sits 1.3-fold (0.10 log units) above what was measured, within the range that was stated.
By their numbers in this assay, from the lowest: compounds 4, 1 and 3 (each within the scatter of the next); then compound 2.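

Among the compounds shown here, this is the first step read at this position. In this assay, 3,4-dichlorophenyl in place of 4-bromophenyl on a saturated chain carbon bound to an aromatic carbon and a saturated chain carbon gives a 1.5-fold lower number from compound 3 to compound 4 (0.18 log units; within the scatter), so the two groups cannot be told apart on this read-out, even though the entering group has 8 heavy atoms against 7 and carries two chlorine atoms rather than one bromine. The position therefore tolerates this exchange of one halogen pattern for another without a readable change, though that holds for this single pair alone, and nothing on hand bears on why the two groups read alike.

The compounds shown leave open how far this tolerance extends, since a single step within the scatter sets no limit on what the position accepts. An unsubstituted phenyl ring, a cyclohexyl ring or a phenyl ring bearing an amine or a carboxylic acid at this carbon could each read alike or move beyond the scatter, and the pair gives no guide to which.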